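From Hydroxy to Methoxy: Expecting Compound 3

A few compounds are considered here, and "the series" means these few. Any claim that something is new, unique, unknown or untested is made for them only; others in the source may bear on it.

Compound 1 `COc1cc(Cl)cc(-c2nn(-c3cccc(NC(=O)Nc4cccc(C(F)(F)F)c4)c3)cc2-c2ccncc2)c1`: 13.2%
Compound 2 `O=C(Nc1cccc(-n2cc(-c3ccncc3)c(-c3cc(O)cc(Cl)c3)n2)c1)Nc1ccc(Cl)c(Cl)c1`: -72.1%

Of the compounds shown here, two have been measured in a functional assay on 786-0 cells (Homo sapiens) for inhibition, read by sulforhodamine B assay, with a stated time of 48 h, tested at 10 uM; a lower number here means a stronger effect, a higher number a weaker effect of the compound at the concentration tested. Compound 2 gives -72.1%, the lowest of the two numbers and so the stronger effect shown; compound 1 gives 13.2%, a number beyond the scatter above it. Compound 3 `COc1cc(Cl)cc(-c2nn(-c3cccc(NC(=O)Nc4ccc(Cl)c(Cl)c4)c3)cc2-c2ccncc2)c1` is not yet measured. It differs from compound 2 by methyl in place of hydrogen on an oxygen on an aromatic ring. Compound 1 also carries a methoxy group, though its urea end differs. Among the measured compounds shown here, no step between measured compounds is known, so the step of a number 42.1 percentage points higher from compound 2 to compound 3 (beyond the scatter) is expected to run upward, toward a weaker effect, but its size is uncertain. Compound 3 is estimated at -30%, within -75% to 20%.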

Compound 3, a percentage reported as activity, at one concentration (the size of the read-out at that concentration, not a potency): 19.6%
Compound 3: the middle estimate sits 49.6 percentage points below what was measured, within the range that was stated.
By their numbers in this assay, from the lowest: compound 2; then compounds 1 and 3 (each within the scatter of the next).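

In this assay, the change from hydroxy to methoxy on the 3-chloro-5-hydroxyphenyl group gives a number 91.7 percentage points higher from compound 2 to compound 3 (beyond the scatter) and so shows that a single methyl on this oxygen can decide the outcome. With methoxy in place, the urea end changes with a number 6.4 percentage points higher from compound 1 to compound 3 (within the scatter) and the two aryl groups there cannot be told apart. Nothing available explains the size of the hydroxy to methoxy step.

The compounds shown leave open whether an amine or an ethoxy group in place of the hydroxy would retain the effect of compound 2. Also open, going by these compounds, is whether hydroxy produces a similar step alongside 3-(trifluoromethyl)phenyl.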